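Opening a Piperidine Ring on a Triazolopyrimidine Core

The compounds below may be only part of what the source reports. "The series", "measured", "known", "first", "only" and "open" are said of these compounds alone.

Measured compounds:
compound 1 `Cc1nc(N2CCCCC2)c2nnn(-c3ccc(C(C)C)cc3Br)c2n1`, 46 nM
compound 2 `CCCCN(CC)c1nc(C)nc2c1nnn2-c1c(Br)cc(OC)cc1OC`, 3 nM

Of the compounds shown here, two have been measured in an in vitro assay on 293-EBNA cells for binding affinity to corticotropin-releasing factor receptor 1 (Homo sapiens); on this read-out lower numbers stand for stronger inhibition and higher numbers for weaker inhibition. Compound 1 gives 46 nM, the highest of the two numbers. Compound 2 differs from compound 1 in several places. Compound 2 gives 3 nM. This number lies far enough below that of compound 1 to be beyond the usual scatter. Among the measured compounds shown here, no single step between these two can be drawn from their structures, so the pair shows only that a lower number is reachable on this core.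

Compound 3 `CCCCC(CCCC)Nc1nc(C)nc2c1nnn2-c1ccc(C(C)C)cc1Br` has not yet been measured. It keeps the aryl part of compound 1 and changes only the amine: a group of 10 heavy atoms (9 carbon, 1 nitrogen; no ring) in place of a group of 6 heavy atoms (5 carbon, 1 nitrogen; one six-membered non-aromatic ring with 1 hetero atom), on an aromatic carbon. The incoming group sits on the aromatic carbon next to the ring nitrogen, ortho to a fused ring and meta to the methyl group.

For the measured compounds named here, since no measured step covers this change, the direction is uncertain. Going by the values given here, compound 2, the only other measured compound, carries an open-chain amine and gives 3 nM, which makes a lower number for compound 3 seem plausible. Compound 3 is therefore expected to reach about 15 nM, within a range from 4 nM to 60 nM, a step from compound 1 of a 3.1-fold lower number from compound 1 to compound 3 (0.49 log units; beyond the scatter).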

Compound 3, inhibition constant: 4.5 nM
Compound 3: middle estimate off by 3.3-fold (0.52 log units), on the high side, within the range that was stated.
By their numbers in this assay, from the lowest: compounds 2 and 3 (each within the scatter of the next); then compound 1.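

In this assay, among the compounds shown here, with the aryl part held constant, exchanging the piperidin-1-yl on this aromatic carbon for the larger open-chain amine gives a 10-fold lower number from compound 1 to compound 3 (1.01 log units; beyond the scatter) in a single change, the first step at this position that can be read in one place. The position therefore accepts a group with no ring, more heavy atoms and a hydrogen-bond donor, which the piperidin-1-yl lacks, and on this aryl part the exchange lowers the number well beyond the usual scatter. No independent measurement bears on what lies behind this step.

The loss of the ring, the larger size of the group and the gain of the amine hydrogen all arrive together, so this one step cannot say which of them accounts for the lower number. A dibutylamino group would keep open chains without the amine hydrogen and a cyclohexylamino group would keep a ring with it, so either one on this carbon would begin to separate these features, while a shorter pentan-3-ylamino group would test how much of the chain length is needed.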